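The source may report more compounds than this note shows. Statements on the series, on what has been measured and on what is new or still open speak of the compounds shown alone.

Compound 1 `COc1ccc(Cn2c(=O)n(C3OC(CO)[C@@H](O)[C@H]3O)c3nc(N)nc(O)c32)cc1` is the stronger of the two measured compounds in a functional assay on the whole organism (B cells) with Mus musculus as the target (a higher number here means a larger maximal response, a lower number a smaller maximal response), where compound 1 gives 44%. For the measured compounds named here, its only neighbour, compound 2 `Nc1nc(O)c2c(n1)n(C1OC(CO)[C@@H](O)[C@H]1O)c(=O)n2Cc1ccc(OCc2ccccc2)cc1`, gives 5% in this assay, and the single step between them, a number 39 percentage points lower from compound 1 to compound 2 (beyond the scatter), comes from a phenyl in place of hydrogen on a saturated chain carbon bound to an oxygen on an aromatic ring.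

Compound 3 `Nc1nc(O)c2c(n1)n(C1OC(CO)[C@@H](O)[C@H]1O)c(=O)n2CCN1CCCCC1` differs from compound 1 at another place: (piperidin-1-yl)methyl in place of 4-methoxyphenyl on a saturated chain carbon bound to an aromatic nitrogen. Going by the values given here, no measured step touches the saturated chain carbon bound to an aromatic nitrogen, so the step to compound 2 shows only that this assay reacts strongly to a change elsewhere and gives no direction for the present one. The estimate for compound 3 in this assay therefore stays close to compound 1 with a wide range, at 30% between 5% and 60%. The expected step is a number 14 percentage points lower from compound 1 to compound 3 (beyond the scatter).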

Compound 3, largest response reached (reported as maximal response), in percent of the reference or control that the assay uses: 0%
Compound 3: the middle estimate sits 30 percentage points above what was measured; the whole stated range lies above it.
By their numbers in this assay, from the lowest: compounds 3 and 2 (each within the scatter of the next); then compound 1.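

The saturated chain carbon bound to an aromatic nitrogen turns out to be a sensitive place: in this assay, replacing 4-methoxyphenyl with (piperidin-1-yl)methyl gives a number 44 percentage points lower from compound 1 to compound 3 (beyond the scatter). For the compounds shown here, the only earlier step had changed a saturated chain carbon bound to an oxygen on an aromatic ring, so this is the first sign that the response of compound 1 also depends on the group at this second place. Here, the 4-methoxybenzyl to 2-(piperidin-1-yl)ethyl exchange leaves no measurable benefit of the new group in this assay. Nothing measured explains this loss of response.

Going by these compounds alone, the single step changes the ring and the chain together, so it leaves open which of the two matters. A 2-phenylethyl group or a plain benzyl group at this place would begin to separate them.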